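Ester in Place of Cyano: Expected Cytotoxicity of Compound 4

A few compounds are considered here, and "the series" means these few. Any claim that something is new, unique, unknown or untested is made for them only; others in the source may bear on it.

Compound 1 `CCCOc1ccc2oc(/C=C/[S+](C)[O-])cc(=O)c2c1` — 6200 nM
Compound 2 `Cc1ccc2oc(/C=C/[S+](C)[O-])cc(=O)c2c1` — 7000 nM
Compound 3 `C[S+]([O-])/C=C/c1cc(=O)c2cc(C#N)ccc2o1` — > 10000 nM (a limit)

In a functional assay on DLD-1 cells (Homo sapiens) for cytotoxicity, with a stated time of 48 h (on this read-out lower numbers stand for stronger inhibition and higher numbers for weaker inhibition), compound 1 gives 6200 nM and compound 2 gives 7000 nM. Among the measured compounds shown here, compound 3 reaches only the limit of the assay, > 10000 nM, so for compound 3 there is a bound and not a number; it is the one value sitting at the limit of > 10000 nM in this assay, at which 1 of the 3 values shown sits. Compound 4 `CC(C)C(=O)Oc1ccc2oc(/C=C/[S+](C)[O-])cc(=O)c2c1` differs from compound 3 by (isopropylcarbonyl)oxy in place of cyano on an aromatic carbon.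

For the measured compounds named here, two measured steps concern this position on the shared core: an at least 1.6-fold higher number from compound 1 to compound 3 (0.20 log units; that floor lies within the scatter) and an at least 1.4-fold higher number from compound 2 to compound 3 (0.15 log units; that floor lies within the scatter). Both are floors whose lower ends lie within the scatter, so the cyano compound stands at the weak end without a measured gap beyond noise. Compound 1, carrying propoxy at the same position, gives 6200 nM. Compound 4 is therefore expected to return a number near that of compound 1 rather than a limit, at 7000 nM, with a range from 3000 nM to 20000 nM. This estimate means an expected step of an at least 1.4-fold lower number from compound 3 to compound 4 (0.15 log units; that floor lies within the scatter).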

Compound 4, half-maximal inhibitory concentration: 9100 nM
Estimate against measurement, compound 4: 1.3-fold (0.11 log units) below; measured number inside the range.
By their numbers in this assay, from the lowest: compounds 1, 2 and 4 (each within the scatter of the next). At a limit, above all of these: compound 3.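

In this assay, (isopropylcarbonyl)oxy in place of cyano on the shared core returns a measured number and not a limit, with an at least 1.0-fold lower number from compound 3 to compound 4 (0.04 log units; that floor lies within the scatter) as the step, a floor that does not clear the scatter. Against the other two compounds the new group also stays within the scatter, with a 1.3-fold higher number from compound 2 to compound 4 (0.11 log units; within the scatter) and a 1.5-fold higher number from compound 1 to compound 4 (0.17 log units; within the scatter) as its steps, so methyl, propoxy and (isopropylcarbonyl)oxy at this aromatic carbon cannot be told apart here. Among the compounds shown here, compound 3 remains at a limit of the assay, > 10000 nM and this is the only such value of the four: the limit of > 10000 nM in this assay, at which 1 of the 4 values shown sits.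

The compounds shown leave open whether an amine or a carboxylic acid on this aromatic carbon would move the number beyond the scatter. They also leave open whether a longer chain on the oxygen would do so.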